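Swapping the Aromatic Group on Compound 2

The compounds below may be only part of what the source reports. "The series", "measured", "known", "first", "only" and "open" are said of these compounds alone.

Compound 1 `CCc1nc2ccc(Cl)cn2c1C(=O)NCc1ccc2c(c1)CCN(Cc1ccc(C(F)(F)F)cn1)C2`: > 64 ug/mL, a limit of the assay
Compound 2 `CCc1nc2ccc(Cl)cn2c1C(=O)NCc1ccc2c(c1)CCN(Cc1ccc(C(F)(F)F)nc1)C2`: 7 ug/mL

Among the measured compounds shown here, in an ADME assay on Vero cells (Chlorocebus sabaeus) for cytotoxicity, read by MTT assay, with a stated time of 72 h (on this read-out higher numbers stand for lower toxicity in this test and lower numbers for higher toxicity in this test), compound 2 gives the only exact number, 7 ug/mL. Compound 1 stands at > 64 ug/mL, which is a limit and not a number. The next molecule, compound 3 `CCc1nc2ccc(Cl)cn2c1C(=O)NCc1ccc2c(c1)CCN(Cc1ccc(F)cc1)C2`, keeps the shared core but differs from compound 2 as follows: 4-fluorophenyl in place of 6-(trifluoromethyl)pyridin-3-yl on a saturated chain carbon bound to an amine nitrogen in a ring. For the measured compounds named here, this is 4-fluorophenyl in place of 6-(trifluoromethyl)pyridin-3-yl, at the same saturated chain carbon that changed in the only measured step, an at least 9.1-fold lower number from compound 1 to compound 2 (0.96 log units; beyond the scatter). That single step shows that a change at this place can be large, and it points to compound 2 as the low end so far. A moderate rise in this assay is therefore expected, meaning lower toxicity, though one step is a thin guide. The expected step is a 2.9-fold higher number from compound 2 to compound 3 (0.46 log units; beyond the scatter). For compound 3 the estimated value is 20 ug/mL, with an expected range from 6 ug/mL to 64 ug/mL.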

Compound 3, half-maximal cytotoxic concentration: > 64 ug/mL
Compound 3: only a limit was reported; the forecaster's own chance of this, stated with the estimate: 25%; at least 3.2-fold (0.50 log units) between middle value and limit.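

In this assay, 4-fluorophenyl in place of 6-(trifluoromethyl)pyridin-3-yl gives an at least 9.1-fold higher number from compound 2 to compound 3 (0.96 log units; beyond the scatter), which means lower toxicity in this test. The low number of compound 2 therefore now stands apart from two neighbours at this saturated chain carbon, and it does not simply follow from having a trifluoromethyl group on a pyridine ring, since compound 1 also carries one. The step from compound 1 to compound 3 cannot be read, because each of the two compounds has a limit and not a number: the limit of > 64 ug/mL in this assay, at which 2 of the 3 values shown sit.

The step to compound 3 swaps the ring nitrogen and the trifluoromethyl group together, so the compounds shown do not tell which of the two matters. A 4-(trifluoromethyl)phenyl group at this place would help to separate them.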